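Trimming the Para Substituent: From Isopropyl to Methyl

This account rests on a few compounds, and the source may have more. Where it says the series, first, only, none or still open, it means among the compounds named here.

Of the compounds shown here, three sharing one core have been measured in an assay on isolated protein for binding affinity to Equilibrative nucleoside transporter 1 (Homo sapiens); a lower number here means a stronger inhibitor, a higher number a weaker inhibitor. Compound 1 `CC(C)(Sc1ncnc2c1ncn2[C@@H]1O[C@H](CO)[C@@H](O)[C@H]1O)c1ccccc1` gives 21400 nM, compound 2 `O=[N+]([O-])c1ccc(O)c(CSc2ncnc3c2ncn3[C@@H]2O[C@H](CO)[C@@H](O)[C@H]2O)c1` gives 33.1 nM, and compound 3 `CC(C)c1ccc(CSc2ncnc3c2ncn3[C@@H]2O[C@H](CO)[C@@H](O)[C@H]2O)cc1` gives 4790 nM, the second highest of the three numbers, closer to compound 1 than to compound 2. Among the measured compounds shown here, the only measured single change, a 140-fold higher number from compound 2 to compound 3 (2.16 log units; beyond the scatter), swapped the whole aryl group, so it says little about merely shortening one alkyl group. Compound 4 `Cc1ccc(CSc2ncnc3c2ncn3[C@@H]2O[C@H](CO)[C@@H](O)[C@H]2O)cc1` differs from compound 3 by methyl in place of isopropyl on an aromatic carbon. For the measured compounds named here, with no measured step addressing this kind of change, a step no larger than the scatter is expected for a 1.3-fold higher number from compound 3 to compound 4 (0.10 log units; within the scatter). Compound 4 is therefore estimated at 6000 nM, with a range from 2000 nM to 18000 nM.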

Compound 4, half-maximal inhibitory concentration: 457 nM
The estimate for compound 4 lay 13-fold (1.12 log units) above the measured number, and the stated range ends above it.
By their numbers in this assay, from the lowest: compound 2; then compound 4; then compound 3; then compound 1.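

Shortening isopropyl to methyl on this aromatic carbon is not a minor edit: a 10-fold lower number from compound 3 to compound 4 (1.02 log units; beyond the scatter) shows that this small group alone can shift the number beyond the scatter. The 4-methylphenyl group still trails 2-hydroxy-5-nitrophenyl, with a 14-fold higher number from compound 2 to compound 4 (1.14 log units; beyond the scatter) on that swap, yet 4-methylbenzyl on the sulfur far outdoes 1-methyl-1-phenylethyl, with a 47-fold lower number from compound 1 to compound 4 (1.67 log units; beyond the scatter) on that one. Nothing available explains the gain from the shorter group. Open, going by these compounds, is how an ethyl, a methoxy or a bare hydrogen would read at this position. Two alkyl groups alone cannot define a trend with size.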